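The source may hold more compounds than are shown below. What is called first, only, known or untested is meant among the compounds shown, and "the series" means these compounds.

Compound 1 `COc1ccccc1/C=C1\CCC/C(=C\c2cccc(OC)c2OC)C1=O`: in a functional assay on A549 cells (Homo sapiens) for cytotoxicity, read by MTT assay, with a stated time of 72 h (on this read-out higher numbers stand for weaker inhibition and lower numbers for stronger inhibition), compound 1 gives > 20000 nM, a limit of the assay.
Compound 2 `COc1cc(/C=C2\CCC/C(=C\c3cccc(OC)c3OC)C2=O)ccc1O`: in this assay compound 2 gives > 20000 nM, also a limit of the assay.
Compound 3 `COc1ccc(/C=C2\CCC/C(=C\c3cccc(Cl)c3)C2=O)cc1OC`: in this assay compound 3 gives 11000 nM.

Among the three measured compounds, compound 3 is the only one with an actual number; the other two readings sit at a limit of the assay, (the limit of > 20000 nM in this assay, at which 2 of the 3 values shown sit). For the measured compounds named here, the one recorded step, a step that the two limits leave unreadable from compound 1 to compound 2, runs between two limits and therefore has no readable size, so it gives no guide to any change in potency.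

Compound 4 `COc1ccc(/C=C2\CCC/C(=C\c3cc(Cl)cc(Cl)c3)C2=O)cc1OC` is not yet measured. It differs from compound 3 by chloro in place of hydrogen on an aromatic carbon, that is, 3-chlorophenyl becomes 3,5-dichlorophenyl. Going by the values given here, no measured step touches a chloro group or this ring, so there is nothing in the data to set the direction or size of the change. The expectation for the step from compound 3 to compound 4 in this assay is therefore a 1.2-fold lower number from compound 3 to compound 4 (0.09 log units; within the scatter), a step that is expected to stay within the usual scatter. On that basis compound 4 is estimated to give 9000 nM in this assay, with a range from 3000 nM to 25000 nM, and a real chance that the assay again reports only a limit.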

Compound 4, half-maximal inhibitory concentration: 5500 nM
Beside the measured number, compound 4's estimate is 1.6-fold (0.21 log units) above it, and the stated range covers the measured number.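

In this assay, for the compounds shown here, the exchange of hydrogen for chloro gives a 2.0-fold lower number from compound 3 to compound 4 (0.30 log units; within the scatter) and is the first step in this set of compounds with a readable size. It shows that a second chloro group, meta to a chloro group on the six-membered aromatic ring, leaves the reading as an actual number and not a limit of the assay, while the step stays within the usual scatter. On this single pair, 3-chlorophenyl and 3,5-dichlorophenyl therefore cannot be told apart with confidence, so the position accepts this one extra heavy atom without a clear gain or loss.

Still open, from the compounds shown here alone, is whether a fluoro group, a nitrile or an amine at this place would move the number beyond the scatter, and whether the same chloro step would read alike on the other aromatic ring of the core. Compound 1 and compound 2 stay at a limit of the assay, so they offer no number to set against this pair: the limit of > 20000 nM in this assay, at which 2 of the 4 values shown sit.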